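One Phenyl Fewer on the Chain Carbon

The source may report more compounds than this note shows. Statements on the series, on what has been measured and on what is new or still open speak of the compounds shown alone.

Measured so far:
compound 1 `N=C(NCCCc1c[nH]cn1)NC(=O)C(c1ccccc1)c1ccccc1` — 1050 nM
compound 2 `N=C(NCCCc1c[nH]cn1)NC(=O)CC(c1ccc(F)cc1)c1ccc(F)cc1` — 204 nM
compound 3 `N=C(NCCCc1c[nH]cn1)NC(=O)CC(c1ccccc1)c1ccc(F)c(F)c1` — 53.7 nM

In a functional assay on cardiac atrium for agonist activity at histamine H2 receptor (Cavia porcellus) (on this read-out lower numbers stand for an effect already at smaller amounts and higher numbers for an effect only at larger amounts of compound), compound 1 gives 1050 nM, the highest number of the three; compound 2 sits lower at 204 nM and compound 3 lower still at 53.7 nM, both gaps lying beyond the scatter. Compound 1 thus stands as the one needing the largest amount among the measured set, with compound 2 its nearest neighbour and compound 3 the furthest.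

Compound 4 `CC(C(=O)NC(=N)NCCCc1c[nH]cn1)c1ccccc1` has not yet been measured. It differs from compound 1 in one place: methyl in place of phenyl on a saturated chain carbon bound to an aromatic carbon and a carbonyl carbon. Going by the values given here, no measured pair shows this kind of change, so its effect can only be guessed. Since compound 1 already gives 1050 nM, the weakest of the set, and both more potent compounds carry two aryl groups at that position, the expectation is a move toward higher numbers, a 3.3-fold higher number from compound 1 to compound 4 (0.52 log units; beyond the scatter). Compound 4 is therefore estimated at 3500 nM, with a range from 900 nM to 14000 nM.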

Compound 4, half-maximal effective concentration: 3630 nM
The estimate for compound 4 lay 1.0-fold (0.02 log units) below the measured number, within the range that was stated.
By their numbers in this assay, from the lowest: compound 3; then compound 2; then compound 1; then compound 4.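

In this assay, going by these compounds alone, methyl in place of phenyl on a saturated chain carbon bound to an aromatic carbon and a carbonyl carbon gives a 3.5-fold higher number from compound 1 to compound 4 (0.54 log units; beyond the scatter), the first step in this set that can be read in one place. The step is modest but beyond the scatter, so the exchange of this phenyl for methyl does register in the read-out, although six heavy atoms leave and only one enters. Nothing measured here says why the number rises.

The compounds shown leave open whether hydrogen, ethyl or a cyclohexyl group on this carbon would give a number closer to that of compound 1 or compound 4. Within the data shown here, they also leave open how the same exchange would read in compound 2 or compound 3, where no one-place step is available.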